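This account rests on a few compounds, and the source may have more. Where it says the series, first, only, none or still open, it means among the compounds named here.

Measured so far in an assay on isolated protein for inhibition of tyrosine-protein kinase receptor UFO (Homo sapiens), read by FRET and Z'-LYTE, with a stated time of 1.5 h; a higher number here means a weaker inhibitor, a lower number a stronger inhibitor:

Compound 1 `Cc1ccc2[nH]c(C)c(C(=O)Nc3ccc(Oc4ncnc5[nH]cc(-c6ccccc6)c45)c(F)c3)c(=O)c2c1`: 560 nM
Compound 2 `CCn1c(C)c(C(=O)Nc2ccc(Oc3ncnc4[nH]cc(-c5ccccc5)c34)c(F)c2)c(=O)c2cc(C)ccc21`: 150 nM
Compound 3 `CCCn1c(C)c(C(=O)Nc2ccc(Oc3ncnc4[nH]cc(-c5ccccc5)c34)c(F)c2)c(=O)c2cc(C)ccc21`: 530 nM

Compound 3 stands second highest of these three numbers. Compound 1 sits within the scatter of compound 3, so the two cannot be told apart, while compound 2 lies beyond the scatter below compound 3. All three share one core and differ only in the group carried on a single aromatic nitrogen: hydrogen, ethyl or propyl.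

Compound 4 `Cc1ccc2c(c1)c(=O)c(C(=O)Nc1ccc(Oc3ncnc4[nH]cc(-c5ccccc5)c34)c(F)c1)c(C)n2-c1ccccc1` changes that same position again: phenyl in place of propyl on an aromatic nitrogen. Within the data shown here, three measured steps concern this nitrogen. The step of a 3.7-fold lower number from compound 1 to compound 2 (0.57 log units; beyond the scatter) shows that a small chain can lower the number modestly, yet a 1.1-fold lower number from compound 1 to compound 3 (0.02 log units; within the scatter) shows that a longer chain gives back nothing, and a 3.5-fold higher number from compound 2 to compound 3 (0.55 log units; beyond the scatter) confirms that adding one more chain carbon reverses the gain. A phenyl ring is a different kind of group from any chain measured here, so the evidence offers no direction for it.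

Compound 4 is therefore expected to give 500 nM in this assay, within a range from 150 nM to 2000 nM. This corresponds to an expected step of a 1.1-fold lower number from compound 3 to compound 4 (0.03 log units; within the scatter), that is, no change beyond the scatter, with wide uncertainty.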

Compound 4, half-maximal inhibitory concentration: 620 nM
The estimate for compound 4 lay 1.2-fold (0.09 log units) below the measured number; measured number inside the range.
By their numbers in this assay, from the lowest: compound 2; then compounds 3, 1 and 4 (each within the scatter of the next).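

In this assay, among these compounds, phenyl is the first ring on this aromatic nitrogen, and it cannot be told apart from the propyl chain, with a 1.2-fold higher number from compound 3 to compound 4 (0.07 log units; within the scatter), or from plain hydrogen, with a 1.1-fold higher number from compound 1 to compound 4 (0.04 log units; within the scatter). The ethyl group keeps its place, as a 4.1-fold higher number from compound 2 to compound 4 (0.62 log units; beyond the scatter) shows: compound 2 has the lowest number of the four and is the strongest inhibitor among them, so the gain seen with ethyl does not carry over to either propyl or phenyl. Among these four compounds, ethyl alone stands apart at this position, and no measurement shown here gives a reason for that.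

The compounds shown leave open whether methyl, isopropyl or cyclopropyl on this nitrogen would match the ethyl group, and so how narrow that gain really is. As far as these compounds go, it also remains open whether a benzyl group, or a phenyl ring carrying a fluorine or a methoxy group, would give a number different from that of the plain phenyl ring.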